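From Bromo to Phenyl: An Expected Binding Step

This account rests on a few compounds, and the source may have more. Where it says the series, first, only, none or still open, it means among the compounds named here.

Measured so far in an assay on cell membranes for displacement of a labelled ligand from Neuronal acetylcholine receptor; alpha4/beta2 (Rattus norvegicus); on this read-out higher numbers stand for weaker inhibition and lower numbers for stronger inhibition:
compound 1 `C[N+]12CCC(C1)C1(CC(Br)=NO1)C2` gives 22000 nM
compound 2 `C[N+]1(C)CCCC2(CC(Br)=NO2)C1` gives 50000 nM

Of these two numbers, compound 1 has the lower one, and its gap to compound 2 lies beyond the usual scatter of repeated measurements, so compound 1 is the stronger binder of the pair. Both carry a bromo group on a carbon with a double bond to nitrogen within a charged, three-ring core. Compound 3 `C[N+]12CCC(C1)C1(CC(c3ccccc3)=NO1)C2` keeps the core of compound 1 and differs from it in one place: phenyl in place of bromo on a carbon with a double bond to nitrogen. No measured pair among these compounds shows what such a swap does, so its effect has to be an expectation rather than something read off the data. A bromo is a single heavy atom, whereas a phenyl brings in a whole six-membered aromatic ring; a change of that size is expected to move the number beyond the scatter, and the expectation here is that it moves upward, toward weaker binding. Compound 3 is therefore estimated at 45000 nM, within a range from 10000 nM to 200000 nM, which means an expected step of a 2.0-fold higher number from compound 1 to compound 3 (0.31 log units; beyond the scatter).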

Compound 3, inhibition constant: 38000 nM
For compound 3 the middle estimate is 1.2-fold (0.07 log units) above the measured one; measured number inside the range.
By their numbers in this assay, from the lowest: compounds 1, 3 and 2 (each within the scatter of the next, the first and the last beyond it).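

The swap of phenyl in place of bromo measured in this assay gives a 1.7-fold higher number from compound 1 to compound 3 (0.24 log units; within the scatter) and so does not separate the two compounds. Going by these compounds alone, this is the first measured information on this position, on a carbon with a double bond to nitrogen of the five-membered ring: replacing 1 heavy atom with 6 heavy atoms and adding a six-membered aromatic ring leaves a difference no larger than repeated measurements of the same compound can produce. On the core of compound 1, then, the read-out does not distinguish a lone bromine from a whole phenyl ring, although this single pair cannot be stretched into a rule for other groups. Nothing among the available data explains why these two groups read alike.

Still open, on these data alone, is whether the same swap on the core of compound 2 would give a similarly small step. As far as these compounds go, it also remains unknown whether a different kind of group at this position, such as an amine, a carboxylic acid or a longer carbon chain, or a methoxy group added to the phenyl ring, would move the number beyond the scatter in either direction.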